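Fluoro for hydroxy on the aryl thiosemicarbazone

The source may hold more compounds than are shown below. What is called first, only, known or untested is meant among the compounds shown, and "the series" means these compounds.

Compound 1 `CC1=CC[C@H](C(C)(C)NC(=S)NN)CC1` is the bare hydrazide of the shared core; in a functional assay on MCF7 cells (Homo sapiens) for inhibition, read by sulforhodamine B assay, with a stated time of 48 h (a higher number here means a weaker inhibitor of growth, a lower number a stronger inhibitor of growth), compound 1 gives 46700 nM. Compound 2 `COc1ccc(/C=N/NC(=S)NC(C)(C)[C@H]2CC=C(C)CC2)cc1` carries a methoxyphenyl group and in this assay compound 2 gives 37700 nM. Compound 3 `CC1=CC[C@H](C(C)(C)NC(=S)N/N=C/c2ccc(O)cc2)CC1` is the hydroxy analogue. In this assay compound 3 gives only a limit of the assay, > 100000 nM. Among the measured compounds shown here, the one measured step on this aryl group is an at least 2.6-fold higher number from compound 2 to compound 3 (0.42 log units; beyond the scatter), and compound 3 sits at the limit of > 100000 nM in this assay, at which 1 of the 3 values shown sits, so its true value stays open. Compound 4 `CC1=CC[C@H](C(C)(C)NC(=S)N/N=C/c2ccc(F)cc2)CC1` differs from compound 3 by fluoro in place of hydroxy on an aromatic carbon. For the measured compounds named here, no measured step covers fluoro, but removing the hydroxy donor and acceptor resembles capping the oxygen in compound 2, which gives 37700 nM, so a return toward that level is expected. Compound 4 is therefore estimated at 60000 nM, between 25000 nM and 150000 nM, an expected at least 1.6-fold lower number from compound 3 to compound 4 (0.22 log units; that floor lies within the scatter).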

Compound 4, concentration for total growth inhibition: > 100000 nM
Compound 4: no number, only a limit; the forecaster's own chance of this, stated with the estimate: 35%; middle value at least 1.6-fold (0.22 log units) away from the limit.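

In this assay compound 4 gives only a limit of the assay, > 100000 nM. Fluoro in place of methoxy gives an at least 2.6-fold higher number from compound 2 to compound 4 (0.42 log units; beyond the scatter), so removing the hydroxy donor does not by itself return the series to the level of compound 2. The step between compound 3 and compound 4 cannot be read, and the two hydroxy and fluoro analogues now rest at the same limit: the limit of > 100000 nM in this assay, at which 2 of the 4 values shown sit.

Going by these compounds, how far compound 3 and compound 4 lie past that limit stays open. Also open, on these data alone, is whether an amine or an ethoxy group on the aromatic ring at this place would give a measurable value.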